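A few compounds are considered here, and "the series" means these few. Any claim that something is new, unique, unknown or untested is made for them only; others in the source may bear on it.

Compound 1 `CN1CCN(c2ccc(Cn3c(=O)[nH]c4c(N)nc(C(F)(F)F)cc43)cn2)CC1` and compound 2 `Nc1nc(C(F)(F)F)cc2c1[nH]c(=O)n2Cc1ccc(NCCO)nc1` share one core and differ only at one aromatic carbon. In an in vitro ADME assay on microsomes from liver (Rattus norvegicus) for pharmacokinetics (on this read-out lower numbers stand for slow clearance and higher numbers for fast clearance), compound 1 gives 46 mL.min-1.g-1. Compound 2 gives < 8.5 mL.min-1.g-1, which is a limit of the assay rather than a number. The move from the 4-methylpiperazin-1-yl group to the (2-hydroxyethyl)amino group brought an at least 5.4-fold lower number from compound 1 to compound 2 (0.73 log units; beyond the scatter), and the true size of that step is open at its lower end since compound 2 sits at the limit of < 8.5 mL.min-1.g-1 in this assay, at which 1 of the 2 values shown sits. Compound 3 `CN1CCN(CCN(C)c2ccc(Cn3c(=O)[nH]c4c(N)nc(C(F)(F)F)cc43)cn2)CC1` is the next member; it carries methyl(2-(4-methylpiperazin-1-yl)ethyl)amino in place of (2-hydroxyethyl)amino on an aromatic carbon. For the measured compounds named here, the entering group contains the same 4-methylpiperazin-1-yl ring that compound 1 carries, now held on a methylated amino nitrogen through an ethyl chain, so the only measured step that bears on this change is the one from compound 1 to compound 2, read in reverse. Compound 3 is therefore expected to show a step of an at least 4.7-fold higher number from compound 2 to compound 3 (0.67 log units; beyond the scatter) in this assay, upward and beyond the scatter. Compound 3 is estimated at 40 mL.min-1.g-1, with a range from 12 mL.min-1.g-1 to 120 mL.min-1.g-1.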

Compound 3, intrinsic clearance in microsomes: 15 mL.min-1.g-1
Compound 3: the middle estimate sits 2.7-fold (0.43 log units) above what was measured; low and high end bracket the measured number.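

In this assay, setting the 4-methylpiperazin-1-yl ring away from the aromatic carbon, on a methylated amino nitrogen through an ethyl chain, gave a 3.1-fold lower number from compound 1 to compound 3 (0.49 log units; beyond the scatter). Compound 1 and compound 3 both carry this ring, so at this position, next to the ring nitrogen, the ring's presence alone does not set the read-out; how it is attached also counts. The change from (2-hydroxyethyl)amino to methyl(2-(4-methylpiperazin-1-yl)ethyl)amino gave an at least 1.7-fold higher number from compound 2 to compound 3 (0.24 log units; that floor lies within the scatter), but the floor of that step lies within the scatter and compound 2 has a limit rather than a number, so the two compounds cannot be firmly set apart: the limit of < 8.5 mL.min-1.g-1 in this assay, at which 1 of the 3 values shown sits.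

The compounds shown do not separate the effects of the methyl on the amino nitrogen, the ethyl chain and the ring in the entering group. They also leave open how a dimethylamino group, a morpholine ring or a longer chain ending in a hydroxyl group would read at this aromatic carbon.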